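Para-substituent exchange on the aryl ring, tracheal inhibition

The compounds below may be only part of what the source reports. "The series", "measured", "known", "first", "only" and "open" are said of these compounds alone.

Measured in a functional assay on trachea (Cavia porcellus); a lower number here means a stronger inhibitor, a higher number a weaker inhibitor:
Compound 1 `CCN1CC[C@@]2(OC)OC(N)=C(C#N)[C@@H](c3ccc(Cl)cc3Cl)[C@@H]2C1`: 27100 nM
Compound 2 `CCN1CC[C@@]2(OC)OC(N)=C(C#N)[C@@H](c3ccc(C)cc3)[C@@H]2C1`: 16800 nM

Compound 2 has the lower of the two numbers, but the difference from compound 1 is a 1.6-fold lower number from compound 1 to compound 2 (0.21 log units; within the scatter), so the two stand level within the scatter. Compound 3 `CCN1CC[C@@]2(OC)OC(N)=C(C#N)[C@@H](c3ccc(OC)cc3)[C@@H]2C1` differs from compound 2 by methoxy in place of methyl on an aromatic carbon. Within the data shown here, no measured step bears directly on this exchange; the one step available swaps whole aryl groups and stays within the scatter. The expected step is therefore a 1.1-fold lower number from compound 2 to compound 3 (0.05 log units; within the scatter), none beyond the scatter. Compound 3 is estimated at 15000 nM, within 6000 nM to 40000 nM.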

Compound 3, half-maximal inhibitory concentration: 25500 nM
For compound 3 the middle estimate is 1.7-fold (0.23 log units) below the measured one; measured number inside the range.
By their numbers in this assay, from the lowest: compounds 2, 3 and 1 (each within the scatter of the next).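

In this assay methoxy in place of methyl on an aromatic carbon, para to a large group, gives a 1.5-fold higher number from compound 2 to compound 3 (0.18 log units; within the scatter) and so has no effect that can be told from the scatter at this position. The exchange of the whole aryl group gives a 1.1-fold lower number from compound 1 to compound 3 (0.03 log units; within the scatter) and likewise stays unresolved, leaving the 2,4-dichlorophenyl, 4-methylphenyl and 4-methoxyphenyl compounds level. No evidence on hand accounts for these numbers.

From the compounds shown here alone, whether an amine, a carboxylic acid or a longer chain such as butoxy on this aromatic carbon would move the number beyond the scatter remains open.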